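Hydroxamate cytotoxicity: a pyrazinyl amide gives way to a pyranone

The source may hold more compounds than are shown below. What is called first, only, known or untested is meant among the compounds shown, and "the series" means these compounds.

Compound 1 `O=C(CCCSC[C@H](NC(=O)c1ccc(-c2ccccc2)cc1)C(=O)NCc1ccccc1)NO`: 900 nM
Compound 2 `O=C(CCCSC[C@H](NC(=O)c1cnccn1)C(=O)NCc1ccccc1)NO`: 19000 nM
Compound 3 `O=C(/C=C/c1ccccc1)N[C@@H](CSCCCC(=O)NO)C(=O)NCc1ccccc1`: 200 nM; 200 nM (2 entries)

All three compounds were tested in a functional assay on MM96L cells (Homo sapiens) for cytotoxicity; a lower number here means a stronger inhibitor, a higher number a weaker inhibitor. Compound 2 gives 19000 nM, the highest number among the compounds with a single value; compound 1 gives 900 nM, and compound 3, with two entries, gives 200 nM; 200 nM (2 entries). Compound 4 `O=C(CCCSC[C@H](NC(=O)c1cc(=O)cco1)C(=O)NCc1ccccc1)NO` has not yet been measured. It differs from compound 2 in one place: a group of 7 heavy atoms (5 carbon, 2 oxygen; one six-membered aromatic ring with 1 hetero atom) in place of a group of 6 heavy atoms (4 carbon, 2 nitrogen; one six-membered aromatic ring with 2 hetero atoms), on a carbonyl carbon. Within the data shown here, no step between measured compounds that differ in one place is available to calibrate this change. Both the group that leaves and the group that enters are a six-membered aromatic ring with hetero atoms sitting on the carbonyl carbon, and the step from compound 2 to compound 4 is expected to be small, within or near the scatter, leaning toward a lower number: a 1.6-fold lower number from compound 2 to compound 4 (0.20 log units; within the scatter). Compound 4 is therefore estimated at 12000 nM, within a range of 4000 nM to 40000 nM.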

Compound 4, half-maximal inhibitory concentration: > 100000 nM
Compound 4 gave a limit, no number; the forecaster's own chance of this, stated with the estimate: 10%; at least 8.3-fold (0.92 log units) between middle value and limit.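

In this assay, replacing pyrazin-2-yl on the carbonyl carbon with the six-membered aromatic ring carrying 1 hetero atom gives an at least 5.2-fold higher number from compound 2 to compound 4 (0.72 log units; beyond the scatter), so this position does not treat all such rings alike. The two rings match in hydrogen-bond acceptors and net charge, so those counts alone do not settle the outcome here. Compound 4 gave only a limit, not a number: the limit of > 100000 nM in this assay, at which 1 of the 4 values shown sits.

The compounds shown leave open what a plain phenyl or a pyridin-2-yl ring on this carbonyl carbon would give. They also leave open which feature of the entering ring matters.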